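Working notes: fluoro in place of methyl, compound 2 to compound 4

The source may report more compounds than this note shows. Statements on the series, on what has been measured and on what is new or still open speak of the compounds shown alone.

Compound 1 `O=S(=O)(Nc1ccc2oc(-c3ccccc3)nc2c1)c1ccccc1O` reaches only the limit of an assay on isolated protein for inhibition of malate dehydrogenase, mitochondrial (Sus scrofa), with stated times of 45 min and 30 min (a lower number here means a stronger inhibitor, a higher number a weaker inhibitor), giving > 63000 nM. Compound 3 `COc1cccc(S(=O)(=O)Nc2ccc3oc(-c4ccccc4)nc3c2)c1` in this assay also gives only the limit > 63000 nM. The step that the two limits leave unreadable from compound 1 to compound 3 is therefore unreadable. Compound 2 `Cc1ccccc1S(=O)(=O)Nc1ccc(-c2nc3ccccc3o2)cc1` likewise gives only the limit > 63000 nM in this assay, so its standing is known as a limit and nothing more; every value shown shares this (the limit of > 63000 nM in this assay, at which 3 of the 3 values shown sit). Compound 4 `O=S(=O)(Nc1ccc(-c2nc3ccccc3o2)cc1)c1ccccc1F` differs from compound 2 as follows: fluoro in place of methyl on an aromatic carbon. Going by the values given here, no measured step involves this change, and the single measured step is unreadable, so neither direction nor size can be read from the data. Compound 4 is expected to remain at the limit, estimated at 100000 nM with a range of 40000 nM to 300000 nM. The expected step is a step that the limit leaves unreadable from compound 2 to compound 4.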

Compound 4, half-maximal inhibitory concentration: > 63000 nM
Compound 4: only a limit was reported; the forecaster's own chance of this, stated with the estimate: 85%; the middle value lies beyond the limit too.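

The step from compound 2 to compound 4 cannot be read, as both compounds stand only at a limit: the limit of > 63000 nM in this assay, at which 4 of the 4 values shown sit.

The compounds shown leave open how strongly any of them inhibits in this assay, and so what fluoro in place of methyl does there.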